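Oral exposure notes: from compound 2 to compound 3

This account rests on a few compounds, and the source may have more. Where it says the series, first, only, none or still open, it means among the compounds named here.

Measured so far in an ADME assay on the whole organism (plasma, strain Swiss Webster) for pharmacokinetics, with Mus musculus as the target, using cassette dosing, at a dose of 0.3 mg/kg by the oral route; on this read-out lower numbers stand for lower exposure and higher numbers for higher exposure at the dose given:
- compound 1 `CCC(C)C(=O)N1CCC(NC(=O)Nc2ccc(C(C)C)cc2)CC1`: 69.1 ng.h/mL
- compound 2 `CCC(C)C(=O)N1CCC(NC(=O)Nc2ccc(C(F)(C(F)(F)F)C(F)(F)F)cc2)CC1`: 754 ng.h/mL

Compound 2 stands as the higher of the two measured compounds in this assay, at 754 ng.h/mL. Going by the values given here, the only measured step is an 11-fold higher number from compound 1 to compound 2 (1.04 log units; beyond the scatter), which is large and beyond the scatter. That step puts 1,2,2,2-tetrafluoro-1-(trifluoromethyl)ethyl in place of isopropyl on an aromatic carbon.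

Compound 3 `O=C(Nc1ccc(C(F)(C(F)(F)F)C(F)(F)F)cc1)NC1CCN(C(=O)CC(F)(F)F)CC1` keeps the group of compound 2 on the aromatic carbon and differs in one place: 2,2,2-trifluoroethyl in place of sec-butyl on a carbonyl carbon. This is 2,2,2-trifluoroethyl in place of sec-butyl on a carbonyl carbon. Among the compounds with values here, no measured step covers a change at this carbonyl carbon, so the data give neither its size nor its direction. The step of an 11-fold higher number from compound 1 to compound 2 (1.04 log units; beyond the scatter) bears on it only indirectly: it shows that one change moved the number a long way here, which argues for a wide range. The expected step is a 1.7-fold lower number from compound 2 to compound 3 (0.22 log units; within the scatter), small and leaning slightly downward as a matter of judgement. For compound 3 the estimated value is 450 ng.h/mL, with an expected range of 130 ng.h/mL to 1500 ng.h/mL.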

Compound 3, area under the concentration-time curve in the Mus musculus assay: 4770 ng.h/mL
Beside the measured number, compound 3's estimate is 11-fold (1.03 log units) below it; measured number outside the range, above it.
By their numbers in the Mus musculus assay, from the lowest: compound 1; then compound 2; then compound 3.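

The carbonyl substituent on the ring nitrogen is a second place on the shared core where one change moves oral exposure beyond the scatter: in the Mus musculus assay, 2,2,2-trifluoroethyl in place of sec-butyl gives a 6.3-fold higher number from compound 2 to compound 3 (0.80 log units; beyond the scatter). In a physicochemical assay for solubility, in phosphate buffer, at pH 7.4 (on this read-out higher numbers stand for higher solubility and lower numbers for lower solubility), the same change gives a 72-fold higher number from compound 2 to compound 3 (1.86 log units; beyond the scatter), so this position also bears on solubility, which the earlier step at the aromatic carbon could not show. In the physicochemical assay compound 2 gives 0.17 ug/mL and compound 3 gives 12.3 ug/mL. The higher exposure of compound 3 may be due to its higher solubility, although a single pair cannot set this apart from other causes: the measured solubility of compound 2, 0.17 ug/mL, and of compound 3, 12.3 ug/mL, a 72-fold higher number (1.86 log units; beyond the scatter)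

Only this pair is shown with both read-outs, so it remains open whether exposure follows solubility across the series or whether compound 3 is a single case. A plain ethyl group on the same carbonyl carbon would show how much of the step belongs to the fluorine atoms and how much to the change from the sec-butyl chain, while a carbonyl substituent bearing an amine would test whether the position tolerates a different kind of group.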